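This account rests on a few compounds, and the source may have more. Where it says the series, first, only, none or still open, it means among the compounds named here.

Two compounds of the series carry measured numbers in an assay on HEK293 cells for binding affinity to Gonadotropin-releasing hormone receptor (Homo sapiens), read by radioligand binding; on this read-out higher numbers stand for weaker inhibition and lower numbers for stronger inhibition. Compound 1 `COc1cccc(-c2c(C)n(Cc3c(F)cccc3F)c(=O)n(C[C@H](N)CC(C)C)c2=O)c1F` gives 6.4 nM, and compound 2 `COc1cccc(-c2c(C)n(Cc3c(F)cccc3F)c(=O)n(C[C@H](NC(C)C)C3CCCC3)c2=O)c1F` gives 12 nM. Going by the values given here, the one measured step, a 1.9-fold higher number from compound 1 to compound 2 (0.27 log units; within the scatter), is within the scatter, so although compound 2 holds the higher of the two numbers, no order between compound 1 and compound 2 can be read from it.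

Compound 3 `COc1cccc(-c2c(C)n(Cc3c(F)cccc3F)c(=O)n(C[C@H](N)C3CCCCC3)c2=O)c1F` is not yet measured. It differs from compound 2 by amino(cyclohexyl)methyl in place of cyclopentyl(isopropylamino)methyl on a saturated chain carbon bound to an aromatic nitrogen. The isopropylamino becomes a plain amino, as in compound 1, and the five-membered ring gives way to a six-membered one. Among the compounds with values here, only the step from compound 1 to compound 2 bears on this change, and it was within the scatter; nothing measured separates the ring exchange from the amine exchange. No step beyond the scatter is therefore expected in this assay. Compound 3 is estimated at 8 nM, with a range from 3 nM to 22 nM. The expected step is a 1.5-fold lower number from compound 2 to compound 3 (0.18 log units; within the scatter).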

Compound 3, inhibition constant: 6.5 nM
Beside the measured number, compound 3's estimate is 1.2-fold (0.09 log units) above it, within the range that was stated.
By their numbers in this assay, from the lowest: compounds 1, 3 and 2 (each within the scatter of the next).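

Going by these compounds alone, the change of isobutyl to cyclohexyl, on a saturated chain carbon bound to an amine nitrogen and a saturated chain carbon, gives a 1.0-fold higher number from compound 1 to compound 3 (0.01 log units; within the scatter) in this assay and is the first exchange confined to this one substituent with the plain amino held fixed. With amino(cyclohexyl)methyl in place of cyclopentyl(isopropylamino)methyl, the reading is a 1.8-fold lower number from compound 2 to compound 3 (0.27 log units; within the scatter) and, like the earlier step, this one still changes the ring and the amine together. Nothing available bears on the reason for these results.

As far as these compounds go, it remains open how the isopropylamino group reads on its own, with the ring held constant. Also open, from the compounds shown here alone, is how a phenyl ring or a carboxylic acid at this position would read in this assay.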